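Amide variation: alkyl and aryl acyl groups compared

The source may hold more compounds than are shown below. What is called first, only, known or untested is meant among the compounds shown, and "the series" means these compounds.

Three compounds have been measured in an assay on LtK cells with ATP-sensitive inward rectifier potassium channel 11 (Homo sapiens) as the target; on this read-out lower numbers stand for an effect already at smaller amounts and higher numbers for an effect only at larger amounts of compound:

compound 1, `CC(C)C(=O)Nc1c(C(O)(C(F)(F)F)C(F)(F)F)ccc2ccccc12`: 6630 nM
compound 2, `CCCC(=O)Nc1c(C(O)(C(F)(F)F)C(F)(F)F)ccc2ccccc12`: 131 nM
compound 3, `N#Cc1cccc(C(=O)Nc2c(C(O)(C(F)(F)F)C(F)(F)F)ccc3ccccc23)c1`: 12 nM

Compound 3 stands at the lowest number of the three. The step of a 550-fold lower number from compound 1 to compound 3 (2.74 log units; beyond the scatter) and the step of an 11-fold lower number from compound 2 to compound 3 (1.04 log units; beyond the scatter) both point the same way, as does a 51-fold lower number from compound 1 to compound 2 (1.70 log units; beyond the scatter): propyl does better than isopropyl on the carbonyl carbon, and 3-cyanophenyl does better than either alkyl group.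

The next compound, compound 4, `O=C(Nc1c(C(O)(C(F)(F)F)C(F)(F)F)ccc2ccccc12)c1cc(Cl)cc(Cl)c1`, keeps everything except the substituents on the aromatic acyl group: 3,5-dichlorophenyl in place of 3-cyanophenyl on a carbonyl carbon. Among the compounds with values here, no measured step covers this kind of exchange. All three steps concern the replacement of one alkyl group by another or of an alkyl group by an aryl group, whereas here one aryl group is set against another. What the steps do show is that an aryl acyl group is strongly favoured, and compound 4 retains one. With nothing in the series that separates one aryl substituent from another, the expected outcome for compound 4 in this assay is a step of a 1.3-fold higher number from compound 3 to compound 4 (0.10 log units; within the scatter), that is, no change beyond the scatter. The estimate for compound 4 is 15 nM, with a range from 4 nM to 60 nM.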

Compound 4, half-maximal effective concentration: 306 nM
Compound 4: the middle estimate sits 20-fold (1.31 log units) below what was measured; the measured number lies above the stated range.
By their numbers in this assay, from the lowest: compound 3; then compound 2; then compound 4; then compound 1.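

In this assay, an aryl acyl group alone does not secure a low number: the exchange of 3-cyanophenyl for 3,5-dichlorophenyl on the carbonyl carbon gives a large step (a 26-fold higher number from compound 3 to compound 4 (1.41 log units; beyond the scatter)), so the substituents on this ring matter. The earlier ranking of aryl over alkyl now holds only in part, since 3,5-dichlorophenyl still outperforms isopropyl (a 22-fold lower number from compound 1 to compound 4 (1.34 log units; beyond the scatter)) but falls modestly behind propyl (a 2.3-fold higher number from compound 2 to compound 4 (0.37 log units; beyond the scatter)), and compound 4 therefore goes against that ranking. Nothing available on this series accounts for the gap between the two aryl groups.

Still open, as far as these compounds go, is whether phenyl without substituents, 3-chlorophenyl or 3,5-dicyanophenyl on the carbonyl carbon would stand closer to compound 3 or to compound 4, which would separate the contribution of the nitrile from that of the two chlorines. Also open, from the compounds shown here alone, is whether a longer chain such as butyl would extend the advantage of propyl over isopropyl or lose it, and how it would compare with the two aryl groups.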